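The compounds below may be only part of what the source reports. "The series", "measured", "known", "first", "only" and "open" are said of these compounds alone.

Among the compounds with values here, compound 2 `CCN1CCN(c2cc(C)c3cc(NC(=O)c4ccc5ccccc5n4)ccc3n2)CC1` gives 3760 nM in a functional assay on SK-BR-3 cells (Homo sapiens) for antiproliferative activity, read by MTT assay, with a stated time of 72 h (on this read-out lower numbers stand for stronger inhibition and higher numbers for weaker inhibition), which puts it second highest of the three numbers measured so far. Compound 1 `Cc1cc(NCCN2CCN(C)CC2)nc2ccc(NC(=O)c3ccc(Cl)c(Cl)c3)cc12` gives 2690 nM in this assay, and the two values lie within the scatter of each other. Compound 3 `Cc1cc(NCCN2CCCC2)nc2ccc(NC(=O)c3ccc(Cl)c(Cl)c3)cc12` gives 9530 nM in this assay, a number beyond the scatter from that of compound 2. Within the data shown here, the only step between measured compounds that differ in one place is a 3.5-fold higher number from compound 1 to compound 3 (0.55 log units; beyond the scatter), a modest shift at the saturated chain carbon.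

Compound 4 `CCN1CCN(c2cc(C)c3cc(NC(=O)c4ccc(C)cc4)ccc3n2)CC1` differs from compound 2 in one place: 4-methylphenyl in place of quinolin-2-yl on a carbonyl carbon. Among the measured compounds shown here, no measured pair changes this group; the step from compound 1 to compound 3 concerns a different part of the molecule and so says nothing about the carbonyl substituent. For the measured compounds named here, compound 1 and compound 3 differ from compound 2 in more than one place, so no single step connects them either.

With nothing to anchor the change, compound 4 is expected to stay near compound 2, and the step of a 1.3-fold higher number from compound 2 to compound 4 (0.12 log units; within the scatter) is the expected outcome, within or only a little beyond the scatter. Compound 4 is estimated at 5000 nM in this assay, within a range from 1500 nM to 16000 nM.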

Compound 4, half-maximal inhibitory concentration: 11400 nM
Estimate against measurement, compound 4: 2.3-fold (0.36 log units) below; low and high end bracket the measured number.
By their numbers in this assay, from the lowest: compounds 1 and 2 (each within the scatter of the next); then compounds 3 and 4 (each within the scatter of the next).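

In this assay the group on the carbonyl carbon turns out to matter: there is a 3.0-fold higher number from compound 2 to compound 4 (0.48 log units; beyond the scatter) when 4-methylphenyl replaces quinolin-2-yl with the rest of the molecule unchanged, a modest shift but one beyond the scatter. Within the data shown here, this is the first measured step at this position, so the number is now known to respond to the group on the carbonyl carbon as well as to the change on the saturated chain carbon. The swap changes several things at once, since quinolin-2-yl has more heavy atoms, a ring with a hetero atom and a hydrogen-bond acceptor, and nothing measured here separates these differences or says why the number moves.

On these data alone, it remains open whether naphthalen-2-yl, which would keep two rings without the ring nitrogen, or pyridin-2-yl, which would keep the ring nitrogen in a single ring, would give a number close to that of compound 2 or that of compound 4. Compound 1 and compound 3 carry a different group on the carbonyl carbon but also differ from compound 2 elsewhere, so they cannot settle how that group ranks.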